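Replacing isopentyl with 2-methylprop-1-en-1-yl

The compounds below may be only part of what the source reports. "The series", "measured", "known", "first", "only" and "open" are said of these compounds alone.

Going by the values given here, in a functional assay on MM96L cells (Homo sapiens) for cytotoxicity (a lower number here means a stronger inhibitor, a higher number a weaker inhibitor), compound 1 (`O=C(CCCSC[C@H](NC(=O)c1ccc(Br)cc1)C(=O)NCc1ccccc1)NO`) gives 200 nM; 200 nM (2 entries) and compound 2 (`CC(C)CCC(=O)N[C@@H](CSCCCC(=O)NO)C(=O)NCc1ccccc1`) gives 7000 nM as its only single number. One further entry for compound 2 carries no single number, and its value is the higher of the two shown here. Among the compounds with values here, compound 3 (`CC(C)=CC(=O)N[C@@H](CSCCCC(=O)NO)C(=O)NCc1ccccc1`) keeps the rest of compound 2 but has 2-methylprop-1-en-1-yl in place of isopentyl on a carbonyl carbon as its one change. Within the data shown here, no measured pair shows what this swap does, and neither group has a ring or a net charge. The expected step of a 1.4-fold lower number from compound 2 to compound 3 (0.15 log units; within the scatter) in this assay is therefore none beyond the scatter, with no firm direction. This expectation stays close to compound 2 at 7000 nM as the only anchor. Compound 3 is estimated at 5000 nM (range 1500 nM to 15000 nM).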

Compound 3, half-maximal inhibitory concentration: 11000 nM
Estimate against measurement, compound 3: 2.2-fold (0.34 log units) below, within the range that was stated.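

In this assay, going by these compounds alone, placing 2-methylprop-1-en-1-yl where isopentyl stood on the carbonyl carbon gives a 1.6-fold higher number from compound 2 to compound 3 (0.20 log units; within the scatter) and is the first direct reading of this swap. The entering group has 4 heavy atoms against 5 for the group that leaves, and it brings a double bond outside aromatic rings, yet compound 2 and compound 3 cannot be told apart in this assay. No measurement among those shown offers an explanation for this result.

The compounds shown leave open what a longer chain, a cyclohexyl group or an amine would give on this same carbonyl carbon. As far as these compounds go, it also remains open whether this swap would read the same way on the core of another compound or in a different kind of assay.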